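From methyl to cyclopropyl on a sulfonyl sulfur

The source may report more compounds than this note shows. Statements on the series, on what has been measured and on what is new or still open speak of the compounds shown alone.

- Compound 1 `Cc1cnc(NC(=O)c2cc(Oc3cnc(C(=O)N(C)C)cn3)c3cc(C)oc3c2)cn1`: < 8 mL/min/kg (a limit)
- Compound 2 `Cc1cnc(NC(=O)c2cc(Oc3cnc(C(=O)N(C)C)cn3)c3cc(C)nn3c2)cn1`: 13.7 mL/min/kg (a number)
- Compound 3 `Cc1cnc(NC(=O)c2cc(Oc3ccc(S(C)(=O)=O)cc3)c3cn(C)nc3c2)cn1`: < 8 mL/min/kg (a limit)
- Compound 4 `Cc1cnc(NC(=O)c2cc(Oc3ccc(S(=O)(=O)C4CC4)cc3)c3cn(C)nc3c2)cn1`: not yet measured

In an in vitro ADME assay on microsomes from liver (Homo sapiens) for metabolic stability (on this read-out lower numbers stand for slow clearance and higher numbers for fast clearance), compound 3 gives < 8 mL/min/kg and this is a limit of the assay, not a number. Compound 1 shares that limit, and compound 2 alone has a number. Compound 4 carries cyclopropyl in place of methyl on a sulfonyl sulfur and keeps the rest of compound 3 unchanged. Going by the values given here, no measured pair shows this change. A small rise in clearance is expected, and the estimated size of a number no lower from compound 3 to compound 4 (the limit leaves the size open) stays close to the usual scatter. For compound 4 the estimated clearance is 8 mL/min/kg with an expected range of 6 mL/min/kg to 14 mL/min/kg (in this assay).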

Compound 4, clearance: < 8 mL/min/kg
Compound 4 gave a limit, no number (the forecaster's own chance of this, stated with the estimate: 55%); the middle value sits exactly at the limit.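

In this assay, going by these compounds alone, compound 3 and compound 4 both give a limit rather than a number, so no step between them can be read: the limit of < 8 mL/min/kg in this assay, at which 3 of the 4 values shown sit. The compounds shown leave open whether cyclopropyl in place of methyl on a sulfonyl sulfur changes clearance at all, and by how much.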